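Chloro-to-amino exchange on a purine-like core

The source may report more compounds than this note shows. Statements on the series, on what has been measured and on what is new or still open speak of the compounds shown alone.

Measured compounds and their numbers in a functional assay on PC-3 cells (Homo sapiens) for cytotoxicity, read by sulforhodamine B assay, with a stated time of 48 h; a lower number here means a stronger inhibitor of growth, a higher number a weaker inhibitor of growth:
compound 1 `ClCc1ccccc1Cn1cnc2c(Cl)nc(Cl)nc21` gives 440 nM;
compound 2 `ClCc1cccc(Cn2cnc3c(Cl)ncnc32)c1` gives 4160 nM;
compound 3 `ClCc1cccc(Cn2cnc3c(Cl)nc(Cl)nc32)c1` gives 2390 nM.

Compound 3 stands second highest of the three numbers in this assay . Its nearest neighbour is compound 2, whose number is higher but within the scatter; the step of a 1.7-fold lower number from compound 2 to compound 3 (0.24 log units; within the scatter) is therefore not a change that can be read as real. Among the measured compounds shown here, compound 1 lies furthest away, with a number lower than that of compound 3 by a margin beyond the scatter, but no single-place step connects them.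

Compound 4 `Nc1nc(Cl)c2ncn(Cc3cccc(CCl)c3)c2n1` differs from compound 3 by amino in place of chloro on an aromatic carbon. For the measured compounds named here, none of the measured steps concerns this kind of exchange; the only step available, chloro in place of hydrogen at the same place, stayed within the scatter. With no bearing evidence, a step of modest size is expected for a 1.5-fold higher number from compound 3 to compound 4 (0.17 log units; within the scatter), more likely towards a higher number. Compound 4 is therefore estimated at 3500 nM in this assay , within a range of 1000 nM to 12000 nM.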

Compound 4, concentration for 50% growth inhibition: 9770 nM
Beside the measured number, compound 4's estimate is 2.8-fold (0.45 log units) below it; the range from low to high includes it.
By their numbers in this assay, from the lowest: compound 1; then compounds 3 and 2 (each within the scatter of the next); then compound 4.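

In this assay, the aromatic carbon between two ring nitrogen atoms had shown no readable change until now, since hydrogen and chloro there lie within the scatter of each other. Amino at this place separates clearly from both: amino in place of chloro gives a 4.1-fold higher number from compound 3 to compound 4 (0.61 log units; beyond the scatter), and amino in place of hydrogen gives a 2.3-fold higher number from compound 2 to compound 4 (0.37 log units; beyond the scatter). The position is therefore not indifferent to what it carries, though nothing at hand explains why amino weakens growth inhibition here.

As far as these compounds go, it remains open whether a substituted amine such as dimethylamino, or a methoxy group, would move the number in the same direction at this place. From the compounds shown here alone, it is equally open whether the same exchange would raise the number of compound 1 , which carries chloro there on a differently substituted benzyl group.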